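Chain substituent and cytotoxicity: acetyl to 4-nitrophenyl

A few compounds are considered here, and "the series" means these few. Any claim that something is new, unique, unknown or untested is made for them only; others in the source may bear on it.

Compound 3 `CC(=O)Cn1cc(CNC(=O)c2cnc(Nc3ccc(C#N)cc3)cc2Oc2c(C)cc(C)cc2C)nn1` gives 19400 nM in an ADME assay on MT4 cells (Homo sapiens) for cytotoxicity, read by MTT assay, with a stated time of 5 days (on this read-out lower numbers stand for higher toxicity in this test and higher numbers for lower toxicity in this test), the lowest of the two numbers in hand. Compound 1 `Cc1cc(C)c(Oc2cc(Nc3ccc(C#N)cc3)ncc2C(=O)NCc2cn(CC(N)=O)nn2)c(C)c1` is nearest with 24000 nM, within the scatter, so no order is read between them. Compound 2 `Cc1cc(C)c(Oc2cc(Nc3ccc(C#N)cc3)ncc2C(=O)NCc2cn(Cc3cccc(F)c3)nn2)c(C)c1` is reported only as a limit of the assay, >= 204000 nM. Compound 4 `Cc1cc(C)c(Oc2cc(Nc3ccc(C#N)cc3)ncc2C(=O)NCc2cn(Cc3ccc([N+](=O)[O-])cc3)nn2)c(C)c1` differs from compound 3 by 4-nitrophenyl in place of acetyl on a saturated chain carbon bound to an aromatic nitrogen. Among the compounds with values here, two measured steps bear on this exchange: an at least 8.5-fold higher number from compound 1 to compound 2 (0.92 log units; beyond the scatter), and an at least 10-fold lower number from compound 2 to compound 3 (1.02 log units; beyond the scatter); both rest on the limit (the limit of >= 204000 nM in this assay, at which 1 of the 3 values shown sits). Compound 4 is therefore expected to move upward in this assay, a 7.7-fold higher number from compound 3 to compound 4 (0.89 log units; beyond the scatter), with a fair chance of again reaching the limit. Compound 4 is estimated at 150000 nM, in the range 40000 nM to 400000 nM.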

Compound 4, half-maximal cytotoxic concentration: >= 139000 nM
Compound 4 ended at the assay's limit; the forecaster's own chance of this, stated with the estimate: 50%; the middle value does not contradict the limit.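

In this assay, 4-nitrophenyl on the saturated chain carbon bound to an aromatic nitrogen gives an at least 7.1-fold higher number from compound 3 to compound 4 (0.85 log units; beyond the scatter), and against carbamoyl it gives an at least 5.7-fold higher number from compound 1 to compound 4 (0.76 log units; beyond the scatter). The high side is therefore not confined to 3-fluorophenyl: among the compounds shown, both groups with a six-membered aromatic ring lie there, while acetyl and carbamoyl do not, and no compound goes against this. Compound 2 and compound 4 are both limits, so the step between them cannot be read.

On these data alone, it remains open whether the ring alone suffices or its substituent also matters. Unsubstituted phenyl, an amine or a carboxylic acid at this place could test that.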